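From 2,4-dichlorophenyl Amide to 1,2-oxazol-3-yl Amide

The source may report more compounds than this note shows. Statements on the series, on what has been measured and on what is new or still open speak of the compounds shown alone.

Three amides sharing one core have been tested in a functional assay on AN3-CA cells (Homo sapiens) for antiproliferative activity, read by MTT assay, with a stated time of 72 h; on this read-out higher numbers stand for weaker inhibition and lower numbers for stronger inhibition. Compound 1 `O=C(Nc1ccc(Cl)c(-c2nnc3c(Cl)cccn23)c1)c1ccc(Cl)cc1` reaches only the limit of the assay, > 100000 nM, which is a limit and not a number. Compound 2 `O=C(Nc1ccc(Cl)c(-c2nnc3c(Cl)cccn23)c1)c1cccc(Cl)c1` gives 68400 nM in this assay. Compound 3 `O=C(Nc1ccc(Cl)c(-c2nnc3c(Cl)cccn23)c1)c1ccc(Cl)cc1Cl` gives 84800 nM in this assay, and so holds the higher of the two numbers, though only through a 1.2-fold higher number from compound 2 to compound 3 (0.09 log units; within the scatter). The other measured steps are an at least 1.4-fold lower number from compound 1 to compound 2 (0.16 log units; that floor lies within the scatter) and an at least 1.1-fold lower number from compound 1 to compound 3 (0.07 log units; that floor lies within the scatter), so none of the changes on the amide side of the molecule has yet produced a difference beyond the scatter.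

Compound 4 `O=C(Nc1ccc(Cl)c(-c2nnc3c(Cl)cccn23)c1)c1ccon1` differs from compound 3 in one place: 1,2-oxazol-3-yl in place of 2,4-dichlorophenyl on a carbonyl carbon. For the measured compounds named here, this change is larger than the earlier ones, which only shifted chlorine atoms around one ring, but those steps are the only guide, and all stayed within the scatter. No step beyond the scatter is therefore expected in this assay. Compound 4 is expected to give about 85000 nM, within 30000 nM to 250000 nM. The implied step, a 1.0-fold higher number from compound 3 to compound 4 (0.00 log units; within the scatter), is expected to remain within the scatter.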

Compound 4, half-maximal inhibitory concentration: > 100000 nM
Compound 4: only a limit was reported (the forecaster's own chance of this, stated with the estimate: 40%); middle value at least 1.1-fold (0.07 log units) away from the limit.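

In this assay, 1,2-oxazol-3-yl on the carbonyl carbon gives an at least 1.1-fold higher number from compound 3 to compound 4 (0.07 log units; that floor lies within the scatter) and an at least 1.4-fold higher number from compound 2 to compound 4 (0.16 log units; that floor lies within the scatter). The earlier compounds shown here only moved or added chlorine on one phenyl ring, whereas this smaller ring with 2 hetero atoms and no chlorine replaces the phenyl ring altogether, and it still gives no number clearly lower than those of the chlorophenyl amides. Compound 1 and compound 4 both reach a limit, not a number, so the step between them cannot be read: the limit of > 100000 nM in this assay, at which 2 of the 4 values shown sit.

From the compounds shown here alone, it remains open whether any group on this carbonyl carbon can bring the number clearly lower while the shared core stays the same. A simple amine, a carboxylic acid on the ring or a longer chain in place of the ring could each test this.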